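The source may report more compounds than this note shows. Statements on the series, on what has been measured and on what is new or still open speak of the compounds shown alone.

In a physicochemical assay for solubility, in phosphate buffer, measured as kinetic solubility, with a stated time of 24 h, at pH 7.4 (on this read-out higher numbers stand for higher solubility and lower numbers for lower solubility), compound 1 (`CC(C)CN(Cc1ccc(N2CCC(O)CC2)cc1)S(=O)(=O)Cc1ccccc1`) gives 7000 nM as a measured number. Compound 2 (`CC(=O)N1CCN(c2ccc(CN(CC(C)C)S(=O)(=O)Cc3ccccc3)cc2)CC1`) stands at <= 1000 nM as a limit and not a number. Compound 3 (`CC(=O)N1CCN(c2ccc(CN(C3CC3)S(=O)(=O)Cc3ccccc3)cc2)CC1`) has cyclopropyl in place of isobutyl on a sulfonamide nitrogen. Among the compounds with values here, the one measured step (an at least 7.0-fold lower number from compound 1 to compound 2 (0.84 log units; beyond the scatter)) lies at another place in the structure, so it sets no size for this change. The estimated step (an at least 1.2-fold higher number from compound 2 to compound 3 (0.07 log units; that floor lies within the scatter)) is therefore expected to stay within the scatter. For compound 3 the expected value is 1200 nM with an estimated range from 400 nM to 4000 nM in this assay when it is measured.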

Compound 3, solubility: 71000 nM
Compound 3: the middle estimate sits 59-fold (1.77 log units) below what was measured; measured number above the stated range.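

Within the data shown here, on the sulfonamide nitrogen, a position the earlier compounds left unchanged, cyclopropyl in place of isobutyl gives an at least 71-fold higher number from compound 2 to compound 3 (1.85 log units; beyond the scatter) in this assay. Neither group carries a hydrogen-bond donor, an acceptor or a net charge, so this position can move the read-out strongly without any such group entering. Compound 2 stands at a limit and not a number, so this step is a floor: the limit of <= 1000 nM in this assay, at which 1 of the 3 values shown sits.

Still open, on these data alone, is whether the three-membered ring itself matters or only the smaller group, which a propyl or cyclobutyl group on the same nitrogen would separate. Also open, as far as these compounds go, is whether the step holds with 4-hydroxypiperidin-1-yl on the aromatic carbon.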